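A few compounds are considered here, and "the series" means these few. Any claim that something is new, unique, unknown or untested is made for them only; others in the source may bear on it.

Compounds measured so far:
Compound 1 `OC[C@H]1O[C@@H](n2cnc3c(NC4CCCCC4)nc(NC4CCCC4)nc32)[C@H](O)[C@@H]1O`: > 500000 nM
Compound 2 `OC[C@H]1O[C@@H](n2cnc3c(N4CCCCC4)nc(NC4CCCC4)nc32)[C@H](O)[C@@H]1O`: "not determined" (no result reported)
Compound 3 `CCCCNc1nc(NC2CCCC2)nc2c1ncn2[C@@H]1O[C@H](CO)[C@@H](O)[C@H]1O`: > 500000 nM

In an ADME assay on HEK-293T cells (Homo sapiens) for cytotoxicity, read by resazurin assay, with a stated time of 16 h (on this read-out higher numbers stand for weaker inhibition and lower numbers for stronger inhibition), compound 3 gives > 500000 nM, which is a limit and not a number. Compound 1 gives > 500000 nM, also a limit. Together they make up (the limit of > 500000 nM in this assay, at which 2 of the 3 values shown sit). Compound 2 has no result to compare.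

Compound 4 `OC[C@H]1O[C@@H](n2cnc3c(NC4CCCCCC4)nc(NC4CCCC4)nc32)[C@H](O)[C@@H]1O` keeps the shared core and has cycloheptyl in place of butyl on a nitrogen on an aromatic ring.

Going by the values given here, only one measured step bears on this change: a step that the two limits leave unreadable from compound 1 to compound 3. It exchanges cyclohexyl and butyl on such a nitrogen, but gives no size to carry over. The expectation therefore rests mainly on compound 1, the measured compound with a ring of carbon on that nitrogen, and on its limit of > 500000 nM.

No step beyond the scatter is expected in this assay, and the expected step is a number no higher from compound 3 to compound 4 (the limit leaves the size open). The assay will most likely report only a limit again. For compound 4 the estimated value is 500000 nM, with an expected range from 150000 nM to 800000 nM.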

Compound 4, half-maximal inhibitory concentration: > 500000 nM
Compound 4: a limit, no number; the forecaster's own chance of this, stated with the estimate: 85%; the middle value sits exactly at the limit.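

In this assay compound 4 gives > 500000 nM, which is a limit and not a number, and its steps from compound 1 and compound 3 cannot be read: the limit of > 500000 nM in this assay, at which 3 of the 4 values shown sit.

The compounds shown leave open whether cyclohexyl, butyl and cycloheptyl on a nitrogen on an aromatic ring differ at all in this assay.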